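A few compounds are considered here, and "the series" means these few. Any claim that something is new, unique, unknown or untested is made for them only; others in the source may bear on it.

Measured compounds:
- compound 1 `O=C(Nc1cccc(/C=C/C(=O)c2nc3ccccc3[nH]2)c1)c1ccccc1`: 2440 nM
- compound 2 `O=C(Nc1cccc(/C=C/C(=O)c2nc3ccccc3[nH]2)c1)c1ccc(Br)cc1`: 2230 nM
- compound 3 `Cc1ccc(C(=O)Nc2cccc(/C=C/C(=O)c3nc4ccccc4[nH]3)c2)cc1`: 1660 nM

All three share the same core and differ only in the group on the carbonyl carbon of the amide. In a functional assay on HCT-116 cells (Homo sapiens) for antiproliferative activity, read by MTT assay, with a stated time of 48 h (a lower number here means a stronger inhibitor, a higher number a weaker inhibitor), compound 3 gives 1660 nM. That is the smallest of the three numbers, but the steps of a 1.5-fold lower number from compound 1 to compound 3 (0.17 log units; within the scatter) and a 1.3-fold lower number from compound 2 to compound 3 (0.13 log units; within the scatter) both fall within the scatter, so nothing separates compound 3 from compound 1 or compound 2 beyond the noise of the measurement.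

Compound 4 `O=C(Nc1cccc(/C=C/C(=O)c2nc3ccccc3[nH]2)c1)c1cc(Cl)cc(Cl)c1` carries a different group at that position: 3,5-dichlorophenyl in place of 4-methylphenyl on a carbonyl carbon. The measured steps that bear on this change are those on the same ring: a 1.1-fold lower number from compound 1 to compound 2 (0.04 log units; within the scatter), a 1.5-fold lower number from compound 1 to compound 3 (0.17 log units; within the scatter) and a 1.3-fold lower number from compound 2 to compound 3 (0.13 log units; within the scatter). Each of them is within the scatter, so swapping hydrogen, bromo and methyl on that ring has so far moved this assay very little. No measured compound carries two chlorines on this ring, so the change to compound 4 is larger than any step seen, but the data give no reason to expect a move beyond the scatter in either direction.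

Compound 4 is therefore expected to give about 1900 nM, in a range from 900 nM to 4200 nM. This corresponds to an estimated 1.1-fold higher number from compound 3 to compound 4 (0.06 log units; within the scatter).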

Compound 4, half-maximal inhibitory concentration: 1650 nM
Estimate against measurement, compound 4: 1.2-fold (0.06 log units) above; measured number inside the range.
By their numbers in this assay, from the lowest: compounds 4, 3, 2 and 1 (each within the scatter of the next).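

In this assay the group on the carbonyl carbon now includes a ring with two chlorines, yet the steps of a 1.0-fold lower number from compound 3 to compound 4 (0.00 log units; within the scatter) and a 1.4-fold lower number from compound 2 to compound 4 (0.13 log units; within the scatter) and a 1.5-fold lower number from compound 1 to compound 4 (0.17 log units; within the scatter) all stay within the scatter. The earlier steps shown here covered only one replacement at a time on this ring, and the flat picture now extends to 3,5-dichlorophenyl: phenyl, 4-bromophenyl, 4-methylphenyl and 3,5-dichlorophenyl cannot be told apart at this position, and none of the four compounds goes against this. Nothing available here explains why these groups give such similar numbers.

From the compounds shown here alone, all four groups are phenyl rings that are either bare or carry only halogen or methyl, so it remains open whether this position would respond to a group of another kind, such as an amine, a carboxylic acid or a longer chain on the ring, or a pyridine ring in place of the phenyl. The compounds shown also leave open whether the same flat picture would hold if a sulfonamide replaced the amide that joins this ring to the shared core.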